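Swapping the amidine arylamine for a benzylidene imine

This account rests on a few compounds, and the source may have more. Where it says the series, first, only, none or still open, it means among the compounds named here.

Compound 3 `COc1ccc(N/C=N/C2=C(C#N)C3C(N4CCCC4)CCCCN3C(=O)N2c2ccccc2)cc1` stands second highest of the three measured compounds in a functional assay on the whole organism (strain albino) for inhibition, with Rattus norvegicus as the target, read by paw edema, with stated times of 1 h and 3 h, at a dose of 20 mmol/kg by the intraperitoneal route (on this read-out higher numbers stand for a stronger effect at the one dose given and lower numbers for a weaker effect), where compound 3 gives 50.2%. Compound 2 `N#CC1=C(/N=C/Nc2ccc([N+](=O)[O-])cc2)N(c2ccccc2)C(=O)N2CCCCC(N3CCCC3)C12` gives 85.6%, and compound 1 `N#CC1=C(NCN2CCCC2)N(c2ccccc2)C(=O)N2CCCCC(N3CCCC3)C12` gives 35.3%. Compound 4 `N#CC1=C(/N=C/c2ccccc2)N(c2ccccc2)C(=O)N2CCCCC(N3CCCC3)C12` differs from compound 3 by phenyl in place of (4-methoxyphenyl)amino on a carbon with a double bond to nitrogen. Among the measured compounds shown here, no measured step removes the aryl-bound nitrogen in this way; the nearest steps are a number 35.4 percentage points lower from compound 2 to compound 3 (beyond the scatter) and a number 14.9 percentage points higher from compound 1 to compound 3 (beyond the scatter), which show that the group on that double-bonded carbon moves the paw edema read-out by large and modest amounts, but in no consistent direction. The step of a number 6.2 percentage points lower from compound 3 to compound 4 (within the scatter) is therefore expected to stay near the scatter, slightly downward. Compound 4 is estimated at 44%, within 24% to 64%.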

Compound 4, a percentage reported as inhibition, in the whole organism at one dose (the size of the read-out at that dose, not a potency): 84%
Compound 4: middle estimate off by 40 percentage points, on the low side; the whole stated range lies below it.
By their numbers in this assay, from the lowest: compound 1; then compound 3; then compounds 4 and 2 (each within the scatter of the next).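

With phenyl in place of (4-methoxyphenyl)amino on a carbon with a double bond to nitrogen, this assay shows a number 33.8 percentage points higher from compound 3 to compound 4 (beyond the scatter), while the same swap for (4-nitrophenyl)amino gives a number 1.6 percentage points lower from compound 2 to compound 4 (within the scatter), so a high read-out at this position does not require the amino nitrogen or a nitro group. Among the compounds shown here, the group in compound 4 also stands well clear of the one in compound 1, with a number 48.7 percentage points higher from compound 1 to compound 4 (beyond the scatter). Nothing available explains these differences. The compounds shown leave open how a phenyl carrying an amine or a carboxylic acid would read at this carbon, or a longer chain in place of phenyl.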